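A few compounds are considered here, and "the series" means these few. Any claim that something is new, unique, unknown or untested is made for them only; others in the source may bear on it.

Compounds measured in a functional assay on HepG2 cells (Homo sapiens) for cytotoxicity, read by MTT assay, with a stated time of 48 h; a higher number here means a weaker inhibitor, a lower number a stronger inhibitor:

compound 1, `COc1ccc(/C=N/NC(=O)CSc2nnc(-c3ccncc3)o2)cc1`, 15800 nM
compound 2, `O=C(CSc1nnc(-c2ccncc2)o1)N/N=C/c1cccc(F)c1`, 19500 nM
compound 3, `O=C(CSc1nnc(-c2ccncc2)o1)N/N=C/c1ccc(O)c(O)c1`, 760 nM

The three compounds share one core and differ only in the aryl group on a carbon with a double bond to nitrogen. Compound 1 holds the second highest of the three numbers. Its nearest neighbour is compound 2: a 1.2-fold higher number from compound 1 to compound 2 (0.09 log units; within the scatter). Its furthest is compound 3: a 21-fold lower number from compound 1 to compound 3 (1.32 log units; beyond the scatter). The same direction is seen between compound 2 and compound 3: a 26-fold lower number from compound 2 to compound 3 (1.41 log units; beyond the scatter).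

Compound 4, `O=C(CSc1nnc(-c2ccncc2)o1)N/N=C/c1ccco1`, has not yet been measured. It differs from compound 1 as follows: furan-2-yl in place of 4-methoxyphenyl on a carbon with a double bond to nitrogen. Of the measured steps, the swap of one aryl group for another without hydroxyl groups, from compound 1 to compound 2, stayed within the scatter, whereas the two large steps each came from the entry of 3,4-dihydroxyphenyl. Furan-2-yl carries no hydrogen-bond donors, so the large steps do not bear directly on it, and the expectation for compound 4 is a step of a 1.1-fold higher number from compound 1 to compound 4 (0.06 log units; within the scatter), that is, none beyond the scatter. Compound 4 is therefore expected to give about 18000 nM in this assay, with a range from 7000 nM to 45000 nM.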

Compound 4, half-maximal inhibitory concentration: 12500 nM
Compound 4: the middle estimate sits 1.4-fold (0.16 log units) above what was measured; the range from low to high includes it.
By their numbers in this assay, from the lowest: compound 3; then compounds 4, 1 and 2 (each within the scatter of the next).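

In this assay, the place on a carbon with a double bond to nitrogen now accepts a change of ring type as well as a change of substituent without a shift beyond the scatter: furan-2-yl in place of 4-methoxyphenyl gives (a 1.3-fold lower number from compound 1 to compound 4 (0.10 log units; within the scatter)), and furan-2-yl in place of 3-fluorophenyl gives (a 1.6-fold lower number from compound 2 to compound 4 (0.19 log units; within the scatter)). A five-membered aromatic ring with 1 hetero atom, smaller than 4-methoxyphenyl at 5 heavy atoms against 8, therefore sits with both six-membered aryl groups, and the large gap to 3,4-dihydroxyphenyl holds against this third group as well (a 16-fold higher number from compound 3 to compound 4 (1.22 log units; beyond the scatter)). Nothing at hand gives a measured reason for compound 3 standing apart from the other three compounds.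

Whether both hydroxyl groups of 3,4-dihydroxyphenyl are needed stays open, since 4-hydroxyphenyl and 3-hydroxyphenyl are not among the compounds shown. Also open, going by these compounds, is how an amine or a carboxylic acid on the aryl ring would read in this assay, and whether a furan ring bearing hydroxyl groups would follow compound 3 or compound 4.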